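The source may report more compounds than this note shows. Statements on the series, on what has been measured and on what is new or still open speak of the compounds shown alone.

Among the measured compounds shown here, in an assay on brain for displacement of a labelled ligand from metabotropic glutamate receptor 5 (Rattus norvegicus) (a lower number here means a stronger inhibitor, a higher number a weaker inhibitor), compound 2 `COc1cccc(C#Cc2csc(N)n2)c1` gives 18.6 nM, the highest number among the three compounds measured so far. Compound 1 `N#Cc1cc(F)cc(C#Cc2csc(Br)n2)c1` gives 0.95 nM, and compound 3 `N#Cc1cc(F)cc(C#Cc2csc(N)n2)c1` gives 0.25 nM; both lie beyond the scatter from compound 2. Compound 4 `COc1cccc(C#Cc2csc(F)n2)c1` differs from compound 2 by one change: fluoro in place of amino on an aromatic carbon. For the measured compounds named here, the single measured step that touches this place is the one where a 3.8-fold lower number from compound 1 to compound 3 (0.58 log units; beyond the scatter), with amino in place of bromo. Compound 4 runs the opposite way, from amino to a halogen, so a modest rise in the number in this assay is expected, a 3.0-fold higher number from compound 2 to compound 4 (0.47 log units; beyond the scatter). Compound 4 is therefore estimated at 55 nM, with a likely range from 20 nM to 160 nM.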

Compound 4, inhibition constant: 22.7 nM
Beside the measured number, compound 4's estimate is 2.4-fold (0.38 log units) above it, and the stated range covers the measured number.
By their numbers in this assay, from the lowest: compound 3; then compound 1; then compounds 2 and 4 (each within the scatter of the next).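

In this assay, fluoro in place of amino on this aromatic carbon gives a 1.2-fold higher number from compound 2 to compound 4 (0.09 log units; within the scatter), so on this core the amino group, with its hydrogen-bond donor and acceptor, can be replaced without a readable change. The earlier step, a 3.8-fold lower number from compound 1 to compound 3 (0.58 log units; beyond the scatter), had amino in place of bromo on a different core and did show a change beyond the scatter, so the amino effect seen there does not carry over here. No measurement offered here explains this difference. On these data alone, it remains open whether a methyl group at this carbon would also leave the number within the scatter, and whether fluoro in place of amino would matter on the core of compound 3.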